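Working notes: aromatic substitution on the shared core

The source may report more compounds than this note shows. Statements on the series, on what has been measured and on what is new or still open speak of the compounds shown alone.

Measured so far:
compound 1 `CC1(C)CC12NC(=O)N(NC(=O)c1ccccc1)C2=O` — 300 mg/kg
compound 2 `CC1(C)CC12NC(=O)N(NC(=O)c1ccc(F)cc1)C2=O` — 100 mg/kg
compound 3 `CC1(C)CC12NC(=O)N(NC(=O)c1ccccc1F)C2=O` — 100 mg/kg

In a functional assay on the whole organism (Hindlimb) for inhibition, with Mus musculus as the target, with a stated time of 0.5 h (on this read-out lower numbers stand for an effect already at smaller amounts and higher numbers for an effect only at larger amounts of compound), compound 1 gives 300 mg/kg and stands at the highest number of the three. Its two neighbours each differ from it by a single fluoro in place of hydrogen on an aromatic carbon: a 3.0-fold lower number from compound 1 to compound 2 (0.48 log units; beyond the scatter) and a 3.0-fold lower number from compound 1 to compound 3 (0.48 log units; beyond the scatter). Between the two fluoro isomers there is no change at the digits printed from compound 2 to compound 3 (within the scatter), so where the fluoro sits made no visible difference in this small set.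

Compound 4 `CC1(C)CC12NC(=O)N(NC(=O)c1ccc(C(F)(F)F)cc1)C2=O` is not yet measured. It differs from compound 1 in one place: trifluoromethyl in place of hydrogen on an aromatic carbon. Among the measured compounds shown here, no measured step introduces trifluoromethyl, so the only bearing comes from the two fluoro steps, both modest and both in the same direction. On that basis a modest step downward in this assay is expected for compound 4, of a size comparable to a 3.0-fold lower number from compound 1 to compound 2 (0.48 log units; beyond the scatter), with a real chance of none beyond the scatter. The expected step is a 2.0-fold lower number from compound 1 to compound 4 (0.30 log units; within the scatter). Compound 4 is therefore estimated at 150 mg/kg, within a range from 60 mg/kg to 400 mg/kg.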

Compound 4, minimum effective dose: 30 mg/kg
Compound 4: the middle estimate sits 5.0-fold (0.70 log units) above what was measured; measured number below the stated range.
By their numbers in this assay, from the lowest: compound 4; then compounds 2 and 3 (each within the scatter of the next); then compound 1.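

In this assay, among the compounds shown here, the aromatic carbon para to a large group turns out not to be exhausted by a single fluoro: trifluoromethyl in place of hydrogen gives a 10-fold lower number from compound 1 to compound 4 (1.00 log units; beyond the scatter) and is the largest step so far. The same place also separates two substituents, since trifluoromethyl in place of fluoro gives a 3.3-fold lower number from compound 2 to compound 4 (0.52 log units; beyond the scatter) and lies beyond the scatter, whereas the earlier comparison of compound 2 and compound 3, the two fluoro isomers, separated nothing. Nothing available explains why this change has the size it has, and no measurement of any property of these compounds bears on it.

Open, as far as these compounds go, is whether this step belongs to trifluoromethyl itself or would come with other groups on the same aromatic carbon, such as chlorine, methoxy, nitrile or an amine. Also open, from the compounds shown here alone, is whether trifluoromethyl keeps this step when it stands where compound 3 carries its fluoro, and whether two substituents on the aromatic ring would add to one another in this whole-organism read-out.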